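Swapping the Bicyclic Amine for an Aminomethylpyrrolidine

A few compounds are considered here, and "the series" means these few. Any claim that something is new, unique, unknown or untested is made for them only; others in the source may bear on it.

Compound 3 `O=C(O)c1cn(Cc2ccc(-n3cccn3)cc2)c2cc(N3CC4CNCC4C3)c(F)cc2c1=O` holds the second highest of the three numbers measured in an assay on isolated protein for inhibition of DNA topoisomerase 1 (Homo sapiens), with a stated time of 15 min (a lower number here means a stronger inhibitor, a higher number a weaker inhibitor), where compound 3 gives 173000 nM. Compound 1 `O=C(O)c1cn(Cc2ccc(-n3cccn3)cc2)c2cc(NC[C@H]3CCNC3)c(F)cc2c1=O` gives 187000 nM in this assay, and the two lie within the usual scatter of each other. Compound 2 `NC[C@@H]1CCN(c2cc3c(cc2F)c(=O)c(C(=O)O)cn3Cc2ccc(-c3ccc(F)cc3)cc2)C1` gives 69600 nM, the lowest of the three and beyond the scatter from compound 3. Compound 4 `NC[C@@H]1CCN(c2cc3c(cc2F)c(=O)c(C(=O)O)cn3Cc2ccc(-n3cccn3)cc2)C1` arises from compound 3 through the change (a group of 7 heavy atoms (5 carbon, 2 nitrogen; one five-membered non-aromatic ring with 1 hetero atom) in place of a group of 8 heavy atoms (6 carbon, 2 nitrogen; 2 five-membered non-aromatic rings with 1 hetero atom each), on an aromatic carbon). Going by the values given here, one measured step bears on it: a 1.1-fold lower number from compound 1 to compound 3 (0.03 log units; within the scatter), which exchanged an amine-bearing group on the same aromatic carbon and barely moved the number. Compound 2 carries the same 3-(aminomethyl)pyrrolidin-1-yl group that enters compound 4, but differs elsewhere in the molecule, so its value is only a loose guide. A small step is therefore expected, and compound 4 is estimated at 120000 nM in this assay, with a range from 50000 nM to 300000 nM. The expected step is a 1.4-fold lower number from compound 3 to compound 4 (0.16 log units; within the scatter).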

Compound 4, half-maximal inhibitory concentration: 91600 nM
Compound 4: the middle estimate sits 1.3-fold (0.12 log units) above what was measured, within the range that was stated.
By their numbers in this assay, from the lowest: compounds 2, 4, 3 and 1 (each within the scatter of the next, the first and the last beyond it).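

At this aromatic carbon, the 3-(aminomethyl)pyrrolidin-1-yl group and the bicyclic amine of compound 3 cannot be told apart in this assay, with a 1.9-fold lower number from compound 3 to compound 4 (0.28 log units; within the scatter). The group changed elsewhere in the molecule also makes no clear difference, since 1H-pyrazol-1-yl in place of 4-fluorophenyl gives a 1.3-fold higher number from compound 2 to compound 4 (0.12 log units; within the scatter). Joining the pyrrolidine through its ring nitrogen instead of using the ((pyrrolidin-3-yl)methyl)amino group gives the only new step beyond the scatter, though a modest one, with a 2.0-fold lower number from compound 1 to compound 4 (0.31 log units; beyond the scatter).

Nothing measured here explains these steps. Going by these compounds, all four compounds keep the carboxylic acid and the fluoro group, so it remains open how the number would respond to an amide in place of that acid or to a piperazine at this aromatic carbon.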